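Replacing the enamide linker of compound 1 with a hydroxypropyl piperidine

The compounds below may be only part of what the source reports. "The series", "measured", "known", "first", "only" and "open" are said of these compounds alone.

Compound 1 `CCc1nn2c(C)cc(C)nc2c1Cc1ccc(/C=C/CN2CCNC(=O)C2)cc1` gives 27 nM in a functional assay on HeLa cells for antagonist activity at G-prodeshotein coupled receptor 4 (Homo sapiens), read by HTRF and cAMP accumulation, with a stated time of 15 min (on this read-out higher numbers stand for weaker inhibition and lower numbers for stronger inhibition), the lowest of the three numbers shown. Compound 2 `CCc1nn2c(C)cc(C)nc2c1Cc1ccc(/C=C/CN2CCN(C(C)C)CC2)cc1` gives 43 nM in this assay, and compound 3 `CCc1nc2c(C)cc(C)nn2c1Cc1ccc(/C=C/CN2CCN(C(C)C)CC2)cc1`, which has a rearranged core, gives 74 nM. Among the compounds with values here, the only single step measured, a 1.6-fold higher number from compound 1 to compound 2 (0.20 log units; within the scatter), shows that exchanging the ring at the chain end costs little. Compound 4 `CCc1nn2c(C)cc(C)nc2c1Cc1ccc(CCC(O)C2CCNCC2)cc1` carries a larger change: 3-hydroxy-3-(piperidin-4-yl)propyl in place of 3-(3-oxopiperazin-1-yl)prop-1-en-1-yl on an aromatic carbon. Within the data shown here, no measured step covers the loss of the double bond or the added hydroxyl, so the swap of terminal ring in the step from compound 1 to compound 2 is the only guide, and a small weakening, near or slightly beyond the scatter, is expected. Compound 4 is estimated at 65 nM (range 15 nM to 280 nM), meaning an expected 2.4-fold higher number from compound 1 to compound 4 (0.38 log units; beyond the scatter).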

Compound 4, half-maximal inhibitory concentration: 24 nM
For compound 4 the middle estimate is 2.7-fold (0.43 log units) above the measured one; low and high end bracket the measured number.
By their numbers in this assay, from the lowest: compounds 4, 1, 2 and 3 (each within the scatter of the next, the first and the last beyond it).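

On this aromatic carbon, para to a large group, the entire side chain can be exchanged with little consequence: 3-hydroxy-3-(piperidin-4-yl)propyl in place of 3-(3-oxopiperazin-1-yl)prop-1-en-1-yl gives, in this assay, a 1.1-fold lower number from compound 1 to compound 4 (0.05 log units; within the scatter) for this exchange. Neither the chain double bond nor the oxopiperazine ring is therefore required for a number in this range. Nothing available explains this tolerance.

Going by these compounds, the separate contributions of the hydroxyl, the saturated chain and the piperidine remain open. Also open, on these data alone, is how a plain propyl chain, a ketone in place of the hydroxyl, or an isopropyl group on the piperidine nitrogen would read.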